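The compounds below may be only part of what the source reports. "The series", "measured", "known", "first", "only" and "open" are said of these compounds alone.

Working notes on the series, a functional assay for activation of Alpha-1B adrenergic receptor (Homo sapiens), read by calcium flux; on this read-out lower numbers stand for smaller maximal responses and higher numbers for larger maximal responses.

Compound 1 `c1cncc(-c2ccccc2OCC2=NCCN2)c1` and compound 2 `c1ccc(-c2ccoc2)c(OCC2=NCCN2)c1` share one core and differ only in the five-membered aromatic ring attached to it. In this assay compound 1 gives 111%. In this assay compound 2 gives 111%. The step of no change at the digits printed from compound 1 to compound 2 (within the scatter) shows that exchanging one five-membered aromatic ring for another at this position leaves the maximal response unchanged. Compound 2 therefore stands level with compound 1 on the numbers at hand; the two values do not differ beyond the scatter.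

Compound 3 `c1ccc(-c2ccsc2)c(OCC2=NCCN2)c1` is not yet measured. Its change from compound 2 is thiophen-3-yl in place of furan-3-yl on an aromatic carbon. Going by the values given here, the only measured step that bears on it is the one from compound 1 to compound 2, which touched the same position with a ring of the same size and the same hetero-atom count and produced no change. On that basis the step of a number 3 percentage points lower from compound 2 to compound 3 (within the scatter) is expected to stay within the scatter. Compound 3 is estimated to reach a maximal response of 108%, with a range from 90% to 125%.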

Compound 3, largest response reached (reported as maximum), in percent of the reference or control that the assay uses: 103%
Compound 3: middle estimate off by 5 percentage points, on the high side, and the stated range covers the measured number.
By their numbers in this assay, from the lowest: compounds 3, 1 and 2 (each within the scatter of the next).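

In this assay, thiophen-3-yl in place of furan-3-yl gives a number 8 percentage points lower from compound 2 to compound 3 (within the scatter), so a sulfur atom can replace the oxygen atom of the five-membered aromatic ring without a step beyond the scatter. Thiophen-3-yl in place of pyridin-3-yl gives a number 8 percentage points lower from compound 1 to compound 3 (within the scatter), which extends the same reading to a second exchange at this aromatic carbon, ortho to a group of 7 heavy atoms, so that pyridin-3-yl, furan-3-yl and thiophen-3-yl cannot be told apart on this read-out. Nothing on hand offers an explanation for these numbers, so the result stands as a description of three compounds and supports no wider rule about aromatic rings at this position.

The compounds shown leave open whether any group at this position moves the maximal response beyond the scatter, since all three carry an unsubstituted aromatic ring joined through a ring carbon. A saturated ring such as cyclohexyl, an aminomethyl group or a carboxylic acid on the attached ring, or a short chain such as propyl in place of the ring, would test how far this tolerance reaches.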